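Methyl to chloro on the aromatic ring: working notes

The compounds below may be only part of what the source reports. "The series", "measured", "known", "first", "only" and "open" are said of these compounds alone.

Measured so far in a functional assay on K562 cells (Homo sapiens) for cytotoxicity, read by MTT assay, with a stated time of 72 h; a higher number here means a weaker inhibitor, a lower number a stronger inhibitor
- compound 1 `C=C1C(=O)[C@@]23C(=O)OC[C@]4(C(=O)CCC(C)(C)[C@H]4C=O)[C@@H]2CC[C@@H]1[C@H]3OC(=O)c1ccc(C)cc1` gives 1270 nM
- compound 2 `C=C1C(=O)[C@@]23C(=O)OC[C@]4(C(=O)CCC(C)(C)[C@H]4C=O)[C@@H]2CC[C@@H]1[C@H]3OC(=O)c1ccc(C(F)(F)F)cc1` gives 2820 nM

Compound 1 holds the lower of the two numbers at 1270 nM in this assay and compound 2 is its nearest neighbour. The next step leads to compound 3 `C=C1C(=O)[C@@]23C(=O)OC[C@]4(C(=O)CCC(C)(C)[C@H]4C=O)[C@@H]2CC[C@@H]1[C@H]3OC(=O)c1ccc(Cl)cc1` with the change chloro in place of methyl on an aromatic carbon on an aromatic carbon, para to a large group, where chloro stands in place of methyl. Among the measured compounds shown here, one measured step bears on this change: a 2.2-fold higher number from compound 1 to compound 2 (0.35 log units; beyond the scatter) for trifluoromethyl in place of methyl on the same aromatic carbon. That step is modest but beyond the scatter. For the measured compounds named here, it is a single example, and no chloro compound has been measured, so the direction is only a tentative guide. A step towards a higher number is expected, smaller than the trifluoromethyl step and possibly not clear of the scatter. The estimated step is a 1.4-fold higher number from compound 1 to compound 3 (0.15 log units; within the scatter) in this reading. The expected value for compound 3 is 1800 nM within an estimated range of 900 nM to 3600 nM in this assay.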

Compound 3, half-maximal inhibitory concentration: 1380 nM
The estimate for compound 3 lay 1.3-fold (0.12 log units) above the measured number; the range from low to high includes it.
By their numbers in this assay, from the lowest: compounds 1 and 3 (each within the scatter of the next); then compound 2.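

In this assay, chloro in place of methyl on this aromatic carbon, para to a large group, gives a 1.1-fold higher number from compound 1 to compound 3 (0.04 log units; within the scatter), so this swap leaves the number unchanged within the scatter and the position accepts chloro as readily as methyl. Chloro in place of trifluoromethyl on the same carbon gives a 2.0-fold lower number from compound 2 to compound 3 (0.31 log units; beyond the scatter), which leaves compound 2 as the only one of the three set apart, while compound 1 and compound 3 stay together; the trifluoromethyl step therefore did not carry over to chloro. Nothing at hand gives a reason for this grouping of the three compounds.

The series shown covers only three groups at this one place, all on the same 4-substituted benzoyl ester of the shared core, so it remains open whether a methoxy group, an amine or a carboxylic acid on this carbon would stay with compound 1 and compound 3 or move away from them. As far as these compounds go, it is also open whether the same grouping would hold with a longer chain in place of the aromatic ring.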